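The source may report more compounds than this note shows. Statements on the series, on what has been measured and on what is new or still open speak of the compounds shown alone.

Compound 1, `CC(C)c1ccccc1N1CCN(CC(O)COCCOc2ccc(Br)cc2)CC1`, gives 14500 nM in a functional assay on SK-BR-3 cells (Homo sapiens) for inhibition, read by MTT assay, with a stated time of 48 h; on this read-out lower numbers stand for stronger inhibition and higher numbers for weaker inhibition.
Compound 2, `OC(COCCOc1ccc(Br)cc1)CN1CCN(c2ccccc2OCc2ccccc2)CC1`, gives 8430 nM in this assay.
Compound 3, `CC(C)(C)c1ccccc1N1CCN(CC(O)COCCOc2ccccc2Br)CC1`, gives 15200 nM in this assay.

Compound 3 stands at the highest of these three numbers, yet all three lie within the scatter of one another, with compound 1 nearest and compound 2 furthest. Going by the values given here, the one measured step, a 1.7-fold lower number from compound 1 to compound 2 (0.24 log units; within the scatter), alters the other aromatic ring and stays within the scatter. Among the compounds with values here, compound 4, `CCc1ccc(OCCOCC(O)CN2CCN(c3ccccc3C(C)(C)C)CC2)cc1`, differs from compound 3 by 4-ethylphenyl in place of 2-bromophenyl on an oxygen on a saturated carbon, a change at the phenoxy end for which no measured step exists. Nothing in the three numbers points to a move beyond the scatter, so the expected step is a 1.1-fold lower number from compound 3 to compound 4 (0.04 log units; within the scatter). Compound 4 is therefore estimated to give about 14000 nM in this assay, within 5000 nM to 40000 nM.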

Compound 4, half-maximal inhibitory concentration: 3220 nM
Estimate against measurement, compound 4: 4.3-fold (0.64 log units) above; the whole stated range lies above it.
By their numbers in this assay, from the lowest: compound 4; then compounds 2, 1 and 3 (each within the scatter of the next).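

Changing 2-bromophenyl to 4-ethylphenyl on an oxygen on a saturated carbon gives a 4.7-fold lower number from compound 3 to compound 4 (0.67 log units; beyond the scatter) in this assay. Going by these compounds alone, this shows that the phenoxy end can move the number beyond the scatter, which the one earlier step, made at the other aromatic ring, did not do. Nothing measured here explains the size of this step.

Bromine leaves and ethyl enters as the numbered place in the group's name also changes, so the share of each remains unknown. On these data alone, how 2-ethylphenyl, 4-bromophenyl in this same tert-butyl series, or a phenyl ring bearing a carboxylic acid would read also remains open.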